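Methoxy to fluoro on the benzylamino arm

The compounds below may be only part of what the source reports. "The series", "measured", "known", "first", "only" and "open" are said of these compounds alone.

Compound 2 `COc1ccc(CNc2nc(-c3ccccc3C(F)(F)F)nc3ccccc23)cc1` gives 6200 nM in an assay on a protein complex for inhibition of ubiquitin carboxyl-terminal hydrolase 1/WD repeat-containing protein 48 (Homo sapiens), read by fluorescence; a lower number here means a stronger inhibitor, a higher number a weaker inhibitor. Compound 1 `Cc1ccc(CNc2nc(-c3ccccc3C(F)(F)F)nc3ccccc23)s1` gives 5100 nM in this assay, and the step of a 1.2-fold higher number from compound 1 to compound 2 (0.08 log units; within the scatter) lies within the scatter, so the two compounds cannot be separated on the numbers in hand; compound 2 is simply one of two indistinguishable values.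

Compound 3 `Fc1ccc(CNc2nc(-c3ccccc3C(F)(F)F)nc3ccccc23)cc1` differs from compound 2 by fluoro in place of methoxy on an aromatic carbon, para to a large group. Among the measured compounds shown here, the single measured step exchanges the whole ring on the saturated chain carbon rather than a substituent on it, and was itself within the scatter, so no measured step bears directly on this change. Compound 3 is therefore expected to give 6000 nM in this assay, with a range of 2500 nM to 15000 nM. The estimated step of a 1.0-fold lower number from compound 2 to compound 3 (0.01 log units; within the scatter) is expected to stay within the scatter.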

Compound 3, half-maximal inhibitory concentration: 3400 nM
Compound 3: middle estimate off by 1.8-fold (0.25 log units), on the high side; measured number inside the range.
By their numbers in this assay, from the lowest: compounds 3, 1 and 2 (each within the scatter of the next).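

In this assay, the change on the aromatic carbon itself, a 1.8-fold lower number from compound 2 to compound 3 (0.26 log units; within the scatter), stays within the scatter, so fluoro and methoxy cannot be separated here, even though the hydrogen-bond acceptor counted on methoxy leaves with it. The exchange of the whole ring, a 1.5-fold lower number from compound 1 to compound 3 (0.18 log units; within the scatter), is also within the scatter, so the 5-methylthiophen-2-yl, 4-methoxyphenyl and 4-fluorophenyl arms cannot yet be told apart on these numbers. No independent measurement bears on this result.

Going by these compounds, it remains open whether any group at this place moves the number beyond the scatter, for example an amine or a carboxylic acid in place of fluoro, or a longer chain between the ring and the amino nitrogen. On these data alone, all three compounds share the same core and trifluoromethyl-bearing ring, so the contribution of those parts also remains open.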